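From Dichlorophenyl to Methylphenyl on the Amine Nitrogen

This account rests on a few compounds, and the source may have more. Where it says the series, first, only, none or still open, it means among the compounds named here.

Compound 1 `Cc1nc(Nc2ccc(Cl)cc2)sc1C(=O)/C=C/c1ccc(Cl)cc1` and compound 2 `Cc1nc(Nc2ccc(Cl)c(Cl)c2)sc1C(=O)/C=C/c1ccc(Cl)cc1` share one core and differ by chloro in place of hydrogen on an aromatic carbon. In a functional assay on Bel-7402 cells (Homo sapiens) for cytotoxicity, read by MTT assay (on this read-out lower numbers stand for stronger inhibition and higher numbers for weaker inhibition), compound 1 gives only a limit of the assay, > 25000 nM. Compound 2 likewise reaches only a limit in this assay, > 25000 nM. The step that the two limits leave unreadable from compound 1 to compound 2 therefore cannot be read, because the limit of > 25000 nM in this assay, at which 2 of the 2 values shown sit, holds both values shown. Compound 2 thus stands at a limit alone, with no number of its own in this assay.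

Compound 3 `Cc1cccc(Nc2nc(C)c(C(=O)/C=C/c3ccc(Cl)cc3)s2)c1` has not yet been measured. It differs from compound 2 by 3-methylphenyl in place of 3,4-dichlorophenyl on a nitrogen on an aromatic ring. Within the data shown here, no measured step bears on this exchange: the only step known, from compound 1 to compound 2, is unreadable, and no other pair is available. Compound 3 is therefore expected to remain near the limit, and its estimated step that the limit leaves unreadable from compound 2 to compound 3 rests on no measured value. Compound 3 is estimated at 30000 nM, in the range 5000 nM to 150000 nM, with a fair chance that this assay again reports only a limit.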

Compound 3, half-maximal inhibitory concentration: > 25000 nM
Compound 3: only a limit was reported; the forecaster's own chance of this, stated with the estimate: 70%; the middle value lies beyond the limit too.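

In this assay compound 3 also gives only a limit, > 25000 nM. Among these compounds, no step from compound 1 or compound 2 to compound 3 can be read, because all three compounds rest at the same limit: the limit of > 25000 nM in this assay, at which 3 of the 3 values shown sit. The compounds shown leave open how strongly compound 1, compound 2 and compound 3 act, and whether exchanging the aryl group on the amine nitrogen changes that at all.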